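Phenyl in Place of Ethyl on the Ring Nitrogen

The compounds below may be only part of what the source reports. "The series", "measured", "known", "first", "only" and "open" are said of these compounds alone.

Compound 1 `CN1CCN(CC(=O)Nc2nc3ccccc3[nH]2)CC1` and compound 2 `CCN1CCN(CC(=O)Nc2nc3ccccc3[nH]2)CC1` share one core and differ only at the amine nitrogen of the six-membered ring. In a functional assay, read by spectrophotometry, with a stated time of 30 min, tested at 200 ug/mL (on this read-out higher numbers stand for a stronger effect at the one concentration tested and lower numbers for a weaker effect), compound 1 gives 61.6%, and in this assay compound 2 gives 65.8%. The step between them, a number 4.2 percentage points higher from compound 1 to compound 2 (within the scatter), is within the scatter. Of the two numbers, compound 2 holds the one reported higher, but since its gap to compound 1 is within the scatter the two compounds are not truly separated.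

Compound 3 `O=C(CN1CCN(c2ccccc2)CC1)Nc1nc2ccccc2[nH]1` is not yet measured in this assay. Its change from compound 2 is phenyl in place of ethyl on an amine nitrogen in a ring. Among the compounds with values here, only one measured step bears on the same ring nitrogen, a number 4.2 percentage points higher from compound 1 to compound 2 (within the scatter), and it was within the scatter; no measured step brings a six-membered aromatic ring to that place, so the information is thin. On that basis no step beyond the scatter is expected in this assay. Compound 3 is therefore estimated at 64%, with a range from 42% to 82%. The expected step is a number 1.8 percentage points lower from compound 2 to compound 3 (within the scatter).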

Compound 3, a percentage reported as activity, at one concentration (the size of the read-out at that concentration, not a potency): 62.1%
The estimate for compound 3 lay 1.9 percentage points above the measured number, within the range that was stated.
By their numbers in this assay, from the lowest: compounds 1, 3 and 2 (each within the scatter of the next).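

On the amine nitrogen in a ring, phenyl in place of ethyl gives a number 3.7 percentage points lower from compound 2 to compound 3 (within the scatter) in this assay and phenyl in place of methyl gives a number 0.5 percentage points higher from compound 1 to compound 3 (within the scatter) and neither step separates the compounds. The earlier compounds shown here varied this nitrogen only between two saturated chains, methyl and ethyl, whereas this result shows that a six-membered aromatic ring of carbon only, larger in heavy atoms than either chain, can stand at the same place with no step beyond the scatter at the one concentration tested. Nothing available explains why the three numbers stay this close, so the result remains an observation without a known cause.

The compounds shown leave open whether any group on this nitrogen would give a step beyond the scatter, for instance a benzyl group, a longer chain such as butyl, or a phenyl ring carrying a chlorine or a methoxy group. They also leave open whether the three compounds would stay together at other concentrations, since a reading at one concentration is not a potency.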